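Trimming the amide aryl group down to plain phenyl

A few compounds are considered here, and "the series" means these few. Any claim that something is new, unique, unknown or untested is made for them only; others in the source may bear on it.

Three measured compounds share one core and differ only in what sits on the amide carbonyl. Compound 1 `COc1cc(-c2nn(-c3cccc(NC(=O)c4cccc(C(F)(F)F)c4)c3)cc2-c2ccncc2)ccc1Cl` gives 2470 nM in a functional assay on SK-MEL-5 cells (Homo sapiens) for inhibition, read by sulforhodamine B assay, with a stated time of 48 h; on this read-out higher numbers stand for weaker inhibition of growth and lower numbers for stronger inhibition of growth. Compound 2 `COc1cc(-c2nn(-c3cccc(NC(=O)Nc4cccc(C(F)(F)F)c4)c3)cc2-c2ccncc2)ccc1Cl` gives 1390 nM in this assay, a change of a 1.8-fold lower number from compound 1 to compound 2 (0.25 log units; within the scatter). Compound 3 `COc1cc(-c2nn(-c3cccc(NC(=O)c4ccc(Cl)c(C(F)(F)F)c4)c3)cc2-c2ccncc2)ccc1Cl` gives 6870 nM in this assay, the highest number of the three; the steps leading to it are a 2.8-fold higher number from compound 1 to compound 3 (0.44 log units; beyond the scatter) and a 4.9-fold higher number from compound 2 to compound 3 (0.69 log units; beyond the scatter).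

Compound 4 `COc1cc(-c2nn(-c3cccc(NC(=O)c4ccccc4)c3)cc2-c2ccncc2)ccc1Cl` has not yet been measured. It differs from compound 3 in one place: phenyl in place of 4-chloro-3-(trifluoromethyl)phenyl on a carbonyl carbon. Only part of this change is covered by measured steps. For the measured compounds named here, the step of a 2.8-fold higher number from compound 1 to compound 3 (0.44 log units; beyond the scatter) shows what adding the chloro did; compound 4 removes that chloro and the trifluoromethyl as well, and no measured pair removes a trifluoromethyl from this ring. The account therefore expects the number to fall back toward that of compound 1, with the uncovered removal of trifluoromethyl leaving the size open. In this assay compound 4 is expected to give about 3000 nM, within a range of 1000 nM to 9000 nM. This estimate means a step of a 2.3-fold lower number from compound 3 to compound 4 (0.36 log units; beyond the scatter), expected to lie beyond the scatter but to remain modest.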

Compound 4, concentration for total growth inhibition: 1380 nM
Compound 4: the middle estimate sits 2.2-fold (0.34 log units) above what was measured; the range from low to high includes it.
By their numbers in this assay, from the lowest: compounds 4, 2 and 1 (each within the scatter of the next); then compound 3.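

With the ring cut back to plain phenyl, the result is a 5.0-fold lower number from compound 3 to compound 4 (0.70 log units; beyond the scatter) in this assay, so the high number of compound 3 does not carry over to every aryl group on this carbonyl carbon. For the compounds shown here, the trifluoromethyl group, whose removal no earlier pair covered, can now be read directly: the change to hydrogen gives a 1.8-fold lower number from compound 1 to compound 4 (0.25 log units; within the scatter), and so, in this pair, the read-out does not depend on that group. Replacing the (3-(trifluoromethyl)phenyl)amino group with phenyl gives a 1.0-fold lower number from compound 2 to compound 4 (0.00 log units; within the scatter), which leaves compound 3 as the only one of the four set apart by a step beyond the scatter, and it is also the only one carrying the chloro on this ring.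

Nothing available explains why the 4-chloro-3-(trifluoromethyl)phenyl group stands apart. Still open, from the compounds shown here alone, is how a lone chloro, a methoxy, an amine or a carboxylic acid on the phenyl ring would read, and whether plain phenylamino on the carbonyl carbon would match phenyl there.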